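The compounds below may be only part of what the source reports. "The series", "measured", "known", "first", "only" and "open" are said of these compounds alone.

Compound 1 `CN(c1cccc2ccccc12)S(=O)(=O)C1CC2OC1C(c1ccc(NC(=O)CCCCCCC(=O)O)cc1)=C2c1ccc(O)cc1` is the starting point of this step. In an ADME assay on Vero cells (Chlorocebus sabaeus) for antiproliferative activity, read by MTT assay, with a stated time of 72 h (a lower number here means a stronger inhibitor, a higher number a weaker inhibitor), compound 1 gives > 100000 nM, which is a limit of the assay and not a number. Compound 2 `CCN(c1ccccc1)S(=O)(=O)C1CC2OC1C(c1ccc(NC(=O)CCCCCCC(=O)O)cc1)=C2c1ccc(O)cc1` carries ethyl(phenyl)amino in place of methyl(naphthalen-1-yl)amino on the sulfonyl sulfur. In this assay compound 2 gives > 100000 nM, again a limit and not a number. The step that the two limits leave unreadable from compound 1 to compound 2 therefore has no readable size; what is known is the limit of > 100000 nM in this assay, at which 2 of the 2 values shown sit. Compound 3 `CCN(c1ccc(Cl)cc1)S(=O)(=O)C1CC2OC1C(c1ccc(NC(=O)CCCCCCC(=O)O)cc1)=C2c1ccc(O)cc1` is not yet measured. It differs from compound 1 as follows: (4-chlorophenyl)(ethyl)amino in place of methyl(naphthalen-1-yl)amino on a sulfonyl sulfur. For the measured compounds named here, the only measured step that bears on this change is the one from compound 1 to compound 2, in which the swap of the amino group on the sulfonyl sulfur left the value at the limit, so no step of readable size is available. The expectation for compound 3 in this assay is that it too sits at the limit, with no shift beyond the scatter, expected as a step that the limit leaves unreadable from compound 1 to compound 3. Compound 3 is estimated at 150000 nM, ranging from 50000 nM to 500000 nM.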

Compound 3, half-maximal inhibitory concentration: > 100000 nM
Compound 3 gave a limit, no number (the forecaster's own chance of this, stated with the estimate: 85%); the middle value is on the limit's open side.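

No new step can be read among compound 1, compound 2 and compound 3 in this assay, since each result is a limit and not a number: the limit of > 100000 nM in this assay, at which 3 of the 3 values shown sit.

The compounds shown leave open whether any group on the sulfonyl sulfur, or any change elsewhere on the shared core, would give a readable value in this assay.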